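The compounds below may be only part of what the source reports. "The series", "measured", "known", "first", "only" and "open" are said of these compounds alone.

Measured in a functional assay on HT-29 cells (Homo sapiens) for inhibition, read by MTT assay, with a stated time of 96 h; on this read-out lower numbers stand for stronger inhibition of growth and higher numbers for weaker inhibition of growth:
Compound 1 `O=C(OCc1ccccc1)SCCCCCCNC(=O)c1cc(-c2ccncc2)n[nH]1`: 22000 nM
Compound 2 `CCC(=O)SCCCCCCNC(=O)c1cc(-c2ccncc2)n[nH]1`: > 50000 nM, a limit of the assay
Compound 3 `CC(=O)SCCCCCCNC(=O)c1cc(-c2ccncc2)n[nH]1`: 23100 nM

Compound 3 stands level with compound 1, as shown by a 1.1-fold higher number from compound 1 to compound 3 (0.02 log units; within the scatter), while compound 2 gave only a limit. Still unmeasured, compound 4 `CSCCCCCCNC(=O)c1cc(-c2ccncc2)n[nH]1` carries methyl in place of acetyl on a sulfur. The measured steps only exchange what sits on the carbonyl carbon, and none removes the carbonyl, so they guide this change only loosely. Taking an at least 2.1-fold lower number from compound 2 to compound 3 (0.33 log units; beyond the scatter) as the closest measure of size, a modest or larger shift towards weaker inhibition of growth is expected in this assay. The expected step is a 1.9-fold higher number from compound 3 to compound 4 (0.29 log units; within the scatter). For compound 4 the estimate is 45000 nM, with an expected range of 22000 nM to 90000 nM.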

Compound 4, concentration for 50% growth inhibition: > 50000 nM
Compound 4: no number, only a limit (the forecaster's own chance of this, stated with the estimate: 60%); middle value at least 1.1-fold (0.04 log units) away from the limit.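

Compound 4 gave only a limit in this assay, and this is the first compound shown with no carbonyl on the sulfur. Methyl in place of acetyl on a sulfur gives an at least 2.1-fold higher number from compound 3 to compound 4 (0.33 log units; beyond the scatter), and methyl in place of benzyloxycarbonyl gives an at least 2.2-fold higher number from compound 1 to compound 4 (0.35 log units; beyond the scatter). As far as these compounds go, the step involving compound 2 cannot be read, and both upper sizes stay open, because these results end at an assay limit: the limit of > 50000 nM in this assay, at which 2 of the 4 values shown sit.

Still open, from the compounds shown here alone, is how a free thiol, with hydrogen on the sulfur, would read. Going by these compounds, an amine in place of acetyl is equally open.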